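Urea series on myeloma cells: one trifluoromethyl removed

A few compounds are considered here, and "the series" means these few. Any claim that something is new, unique, unknown or untested is made for them only; others in the source may bear on it.

Measured so far:
compound 1, `O=C(Nc1cccc(-n2cc(-c3ccncc3)c(-c3cc(O)cc(Cl)c3)n2)c1)Nc1ccc(Cl)c(Cl)c1`: -15.3%
compound 2, `COc1cc(Cl)cc(-c2nn(-c3cccc(NC(=O)Nc4ccc(Cl)c(C(F)(F)F)c4)c3)cc2-c2ccncc2)c1`: -29.1%
compound 3, `COc1cc(Cl)cc(-c2nn(-c3cccc(NC(=O)Nc4cc(C(F)(F)F)cc(C(F)(F)F)c4)c3)cc2-c2ccncc2)c1`: -17.5%

In a functional assay on RPMI-8226 cells (Homo sapiens) for inhibition, read by sulforhodamine B assay, with a stated time of 48 h, tested at 10 uM (a lower number here means a stronger effect, a higher number a weaker effect of the compound at the concentration tested), compound 1 gives -15.3%, compound 2 gives -29.1%, and compound 3 gives -17.5%. All three numbers lie in the weak range of this assay. Compound 3 stands second highest of the three; its nearest neighbour is compound 1, whose number is higher but within the scatter, so no order between compound 1 and compound 3 is claimed. Compound 2 is furthest from compound 3, its number lower by a gap beyond the scatter.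

Compound 4 is `COc1cc(Cl)cc(-c2nn(-c3cccc(NC(=O)Nc4cccc(C(F)(F)F)c4)c3)cc2-c2ccncc2)c1`. It differs from compound 3 in one place: hydrogen in place of trifluoromethyl on an aromatic carbon.

For the measured compounds named here, no step between two measured compounds has been worked out for this series, so the size of this change in this assay rests on the values alone. Compound 2 and compound 3, which carry different groups on the same ring, both sit in the weak range, so the step from compound 3 to compound 4 is expected to be small, in no clear direction, and likely within the scatter. The step of a number 2.5 percentage points lower from compound 3 to compound 4 (within the scatter) is the estimated change. Compound 4 is expected to give about -20%, within -40% to 0%.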

Compound 4, a percentage reported as activity, at one concentration (the size of the read-out at that concentration, not a potency): -14.2%
Beside the measured number, compound 4's estimate is 5.8 percentage points below it; low and high end bracket the measured number.
By their numbers in this assay, from the lowest: compound 2; then compounds 3, 1 and 4 (each within the scatter of the next).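

Hydrogen in place of trifluoromethyl on this aromatic carbon gives a number 3.3 percentage points higher from compound 3 to compound 4 (within the scatter) in this assay, the first one-place step read at this carbon in the series. Hydrogen in place of chloro on another aromatic carbon of the same ring gives a number 14.9 percentage points higher from compound 2 to compound 4 (beyond the scatter) in this assay, so among the compounds shown the chloro place, not the trifluoromethyl place, is where a single change moves the number beyond the scatter. Each of these readings rests on a single step, and nothing on hand accounts for either of them.

As far as these compounds go, whether an amine or a carboxylic acid on the carbon that lost the trifluoromethyl would keep the number in the same range remains open. Also open, from the compounds shown here alone, is whether the step at the chloro place recurs with a methyl or a nitrile in place of chloro.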